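Ester Replacement of the Acid Hydrogen in Compound 1

This account rests on a few compounds, and the source may have more. Where it says the series, first, only, none or still open, it means among the compounds named here.

Measured compounds:
compound 1, `CCCc1nc(C(C)(C)O)c(C(=O)O)n1Cc1ccc(-c2ccccc2C(=O)O)cc1`, gives 12% in a functional assay on the whole organism for inhibition, with Rattus norvegicus as the target, with a stated time of 6 h, at a dose of 1 mg/kg; a lower number here means less inhibition, a higher number more inhibition at the dose given (going by the name of the read-out)
compound 2, `CCCc1nc(C(C)(C)O)c(C(=O)OCOC(=O)C(C)(C)C)n1Cc1ccc(-c2ccccc2C(=O)O)cc1`, gives 75%; 87% (2 entries) in this assay

Compound 1 stands at the low end of what has been measured in this assay: its number is the only single number shown for it, and one further entry carries no single number. Compound 2 has several entries in this assay, (the several entries of compound 2 in this assay, 75%; 87% (2 entries)), which sit well above the number of compound 1. For the measured compounds named here, no step between these two measured compounds is worked out here, so their values are simply placed side by side.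

Compound 3, `CCCc1nc(C(C)(C)O)c(C(=O)OC2OC(=O)c3ccccc32)n1Cc1ccc(-c2ccccc2C(=O)O)cc1`, differs from compound 1 by a group of 10 heavy atoms (8 carbon, 2 oxygen; one five-membered non-aromatic ring with 1 hetero atom, one six-membered aromatic ring of carbon only) in place of a hydrogen atom, on an oxygen next to a carbonyl group. Compound 2 likewise carries an ester grouping on the shared core, and its entries in this assay (the several entries of compound 2 in this assay, 75%; 87% (2 entries)) lie high. On that basis the expected step is a number 58 percentage points higher from compound 1 to compound 3 (beyond the scatter), an increase well beyond the usual scatter. Compound 3 is therefore expected to give about 70% in this assay, within a range from 45% to 90%.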

Compound 3, a percentage reported as inhibition, in the whole organism at one dose (the size of the read-out at that dose, not a potency): 74%
Beside the measured number, compound 3's estimate is 4 percentage points below it; the measured number falls inside the stated range.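

In this assay, the group of 10 heavy atoms (8 carbon, 2 oxygen), set in place of a hydrogen atom on an oxygen next to a carbonyl group, gives a number 62 percentage points higher from compound 1 to compound 3 (beyond the scatter). Before this result, the only ester grouping at this place on the shared core was the one in compound 2, so the high numbers could have belonged to that one group alone. Compound 3 carries a different group, with one five-membered non-aromatic ring and one six-membered aromatic ring, and at 74% it also stands well above compound 1, so across these two compounds a high number in this assay does not depend on a single ester grouping, as the entries for the other ester show: the several entries of compound 2 in this assay, 75%; 87% (2 entries)

The compounds shown do not tell whether a small group on that oxygen, such as methyl or ethyl, would also lift the number, or whether an amide in place of the ester would do so. They also leave open whether the inhibition seen with compound 3 comes from the intact compound or from compound 1 formed from it in the animal.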